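The compounds below may be only part of what the source reports. "The series", "measured", "known", "first", "only" and "open" are said of these compounds alone.

Measured in a functional assay on MCF7 cells (Homo sapiens) for inhibition, read by MTT assay, with a stated time of 72 h; on this read-out higher numbers stand for weaker inhibition and lower numbers for stronger inhibition:
- Compound 1 `COc1ccc(C(=O)/C=C/c2cc(OC)c(OC)cc2OC)cc1`: 33900 nM
- Compound 2 `COc1cc(OC)c(OC)cc1/C=C/C(=O)c1ccc(-c2c[nH]cn2)cc1`: > 150000 nM, a limit
- Compound 3 `COc1cc(OC)c(-c2cc(=O)c3cc(Cl)ccc3o2)cc1OC`: > 150000 nM, a limit

Going by the values given here, compound 1 holds the only actual number in this assay, while the other two compounds stand at the limit of > 150000 nM in this assay, at which 2 of the 3 values shown sit. Compound 4 `COc1cc(OC)c(OC)cc1/C=C/C(=O)c1cc(Cl)ccc1O` differs from compound 1 by one change: 5-chloro-2-hydroxyphenyl in place of 4-methoxyphenyl on a carbonyl carbon. In words, 5-chloro-2-hydroxyphenyl replaces 4-methoxyphenyl on a carbonyl carbon.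

Among the compounds with values here, one measured step bears on this change: an at least 4.4-fold higher number from compound 1 to compound 2 (0.64 log units; beyond the scatter). There, 1H-imidazol-4-yl takes the place of methoxy on an aromatic carbon. That step also removes the methoxy, but the incoming group is different, so it is only a loose guide and gives no exact size.

Within the data shown here, with an at least 4.4-fold higher number from compound 1 to compound 2 (0.64 log units; beyond the scatter) as the sole precedent, a slight shift towards weaker inhibition is expected, though not one clearly beyond the scatter. The expected change is a 1.3-fold higher number from compound 1 to compound 4 (0.12 log units; within the scatter). For compound 4 the estimated value in this assay is 45000 nM, with an expected range from 12000 nM to 150000 nM.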

Compound 4, half-maximal inhibitory concentration: > 150000 nM
Compound 4 ended at the assay's limit (the forecaster's own chance of this, stated with the estimate: 25%); at least 3.3-fold (0.52 log units) between middle value and limit.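

In this assay, replacing 4-methoxyphenyl with 5-chloro-2-hydroxyphenyl on the carbonyl carbon gives an at least 4.4-fold higher number from compound 1 to compound 4 (0.64 log units; beyond the scatter). This shows that the group on the carbonyl carbon matters for this read-out, whereas the earlier step concerned only the replacement of methoxy by 1H-imidazol-4-yl on an aromatic carbon. The value of compound 4 is a limit, so compound 1 remains the only compound with an actual number, and the series offers no second number to compare it with: the limit of > 150000 nM in this assay, at which 3 of the 4 values shown sit.

The compounds shown leave open whether the chlorine or the hydroxyl of the new group accounts for the step, since both enter together. They also leave open whether 2-hydroxyphenyl, 3-chlorophenyl or 4-aminophenyl on the same carbonyl carbon would give a number rather than a limit.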